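Aminophenyl for methylphenyl on the thiophene-urea amide series

A few compounds are considered here, and "the series" means these few. Any claim that something is new, unique, unknown or untested is made for them only; others in the source may bear on it.

Working notes on a small set sharing the core of compound 1 `Cc1ccc(-c2cc(C(=O)N[C@H]3CCCNC3)c(NC(N)=O)s2)cc1`. Going by the values given here, in a functional assay on HT-29 cells (Homo sapiens) (a lower number here means that less compound is needed, a higher number that more compound is needed for the effect), compound 1 gives 70 nM, and this is the only number in the set. Compound 2 `NC(=O)Nc1sc(-c2ccccc2)cc1C(=O)NC1CCCCC1` carries the same core with a cyclohexyl amide; in this assay compound 2 gives "not determined" (no result reported). Compound 3 `CN1CCN(C(=O)c2cc(-c3ccccc3)sc2NC(N)=O)CC1`, the methylpiperazine amide, likewise has no number: in this assay compound 3 gives "not determined" (no result reported). Among the compounds with values here, no step between two measured compounds can therefore be drawn, and compound 1 stands alone as the reference point.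

Compound 4 `NC(=O)Nc1sc(-c2ccc(N)cc2)cc1C(=O)N[C@H]1CCCNC1` has not been measured. It differs from compound 1 in one place (amino in place of methyl on an aromatic carbon); the change leaves the shared core and the piperidinyl amide untouched. Nothing in the measured set shows how this assay responds to a change at that position.

The expectation for compound 4 is a modest loss, with the step of a 2.1-fold higher number from compound 1 to compound 4 (0.33 log units; beyond the scatter) judged likely to sit near or only slightly beyond the usual scatter rather than well outside it. For compound 4 the estimate in this assay is 150 nM, with a range from 40 nM to 500 nM.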

Compound 4, half-maximal effective concentration: 920 nM
Compound 4: middle estimate off by 6.1-fold (0.79 log units), on the low side; measured number outside the range, above it.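

In this assay, going by these compounds alone, going from 4-methylphenyl to 4-aminophenyl gives a 13-fold higher number from compound 1 to compound 4 (1.12 log units; beyond the scatter), the first step in this set that can be read, and it shows that this position is sensitive. The exchange of a single heavy atom, carbon for nitrogen, leaves the shared core and the piperidinyl amide untouched and adds one hydrogen-bond donor and one hydrogen-bond acceptor by count, with no net charge, yet it is enough for a large step in the direction of more compound needed. No measurement at hand speaks to the origin of this step, so it stays a bare observation on one pair.

As far as these compounds go, whether the step belongs to the amino group specifically or would follow other replacements of methyl stays open: a hydroxyl, a methoxy or a dimethylamino group at the same place, or a plain phenyl on the piperidinyl amide, would separate these readings. Steps involving compound 2 and compound 3 cannot be read, so the cyclohexyl and methylpiperazine amides add nothing to the comparison.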